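This account rests on a few compounds, and the source may have more. Where it says the series, first, only, none or still open, it means among the compounds named here.

Three compounds have been measured in an assay on MDA-MB-231 cells for displacement of a labelled ligand from C-X-C chemokine receptor type 4 (Homo sapiens), read by fluorescence and microscopy, with stated times of 10 min and 30 min; on this read-out lower numbers stand for an effect already at smaller amounts and higher numbers for an effect only at larger amounts of compound:

Compound 1 `O=C(NCc1ccc(CNS(=O)(=O)c2ccccc2F)cc1)c1cccnc1` gives 100 nM.
Compound 2 `Cc1ccccc1C(=O)NCc1ccc(CNS(=O)(=O)c2cccc(Cl)c2)cc1` gives 100 nM.
Compound 3 `O=C(NCc1ccc(CNS(=O)(=O)c2cccc(Cl)c2)cc1)c1cccnc1` gives 100 nM.

Compound 2 and compound 3 differ at the amide end, where (2-methylphenyl in place of pyridin-3-yl on a carbonyl carbon); in this assay that change gives no change at the digits printed from compound 2 to compound 3 (within the scatter). Compound 4 `Cc1ccccc1C(=O)NCc1ccc(CNS(=O)(=O)c2ccccc2F)cc1` has not yet been measured. It differs from compound 2 at the sulfonyl end, where (2-fluorophenyl in place of 3-chlorophenyl on a sulfonyl sulfur). The same change occurs once more among these compounds, from compound 3 to compound 1, and its place reads the same word for word; there it gives no change at the digits printed from compound 3 to compound 1 (within the scatter). Because no change at the digits printed from compound 3 to compound 1 (within the scatter) is within the scatter, the step from compound 2 to compound 4 is expected to be no change at the digits printed from compound 2 to compound 4 (within the scatter). Compound 4 is therefore estimated at 100 nM in this assay, between 50 nM and 200 nM.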

Compound 4, effective concentration (reported as EC, without a stated level of effect): 1000 nM
Beside the measured number, compound 4's estimate is 10-fold (1.00 log units) below it; the measured number lies above the stated range.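

In this assay, 2-fluorophenyl in place of 3-chlorophenyl on a sulfonyl sulfur gives a 10-fold higher number from compound 2 to compound 4 (1.00 log units; beyond the scatter), so this change does not carry over unaltered from one core to the other: the same change on two cores in this assay, no change at the digits printed (within the scatter) from compound 3 to compound 1 and a 10-fold higher number (1.00 log units; beyond the scatter) from compound 2 to compound 4, 10-fold (1.00 log units) apart, beyond the scatter of two such steps. The change at the amide end also depends on the core, with 2-methylphenyl in place of pyridin-3-yl on a carbonyl carbon giving a 10-fold higher number from compound 1 to compound 4 (1.00 log units; beyond the scatter): the same change on two cores in this assay, no change at the digits printed (within the scatter) from compound 2 to compound 3 and a 10-fold lower number (1.00 log units; beyond the scatter) from compound 4 to compound 1, 10-fold (1.00 log units) apart, beyond the scatter of two such steps. Among the compounds shown here, neither change can therefore be transferred reliably within this set, but both comparisons rest on the single result for compound 4, and they do not show what lies behind the gap.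

The compounds shown leave open whether this dependence is specific to the pairing of 2-fluorophenyl with 2-methylphenyl. It is also unknown whether it would appear with a 2-chlorophenyl or an unsubstituted phenyl on the sulfonyl sulfur.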